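Swapping Methoxyphenyl for Chlorobenzyl on the Amide Chain

A few compounds are considered here, and "the series" means these few. Any claim that something is new, unique, unknown or untested is made for them only; others in the source may bear on it.

Compound 2 `COc1cccc(CCC(=O)Nc2nc3ccccc3c(=O)s2)c1` carries the highest number among the three compounds measured in an assay on mitochondria (strain Sprague-Dawley) for inhibition of Amine oxidase [flavin-containing] B (Rattus norvegicus), read by fluorescence and Amplex Red, with stated times of 30 min and 45 min; a higher number here means a weaker inhibitor, a lower number a stronger inhibitor: in this assay compound 2 gives 621 nM. Compound 1 `O=C(CCCc1ccccc1)Nc1nc2ccsc2c(=O)s1`, which has a saturated chain of a similar kind on a related core, gives 298 nM, and compound 3 `COc1cccc(C#CC(=O)Nc2nc3ccccc3c(=O)s2)c1` gives 73.9 nM. Compound 4 `O=C(CCCc1cccc(Cl)c1)Nc1nc2ccccc2c(=O)s1` keeps the core of compound 2 and changes only the chain: 3-chlorobenzyl in place of 3-methoxyphenyl on a saturated chain carbon, two bonds along the chain from a carbonyl carbon. Among the compounds with values here, no measured pair shows this exact change, so the expectation leans on compound 1, whose saturated chain gives 298 nM. A moderate move toward a lower number is expected, a 2.1-fold lower number from compound 2 to compound 4 (0.32 log units; beyond the scatter). Compound 4 is therefore estimated at 300 nM, with a likely range from 100 nM to 900 nM.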

Compound 4, half-maximal inhibitory concentration: 6880 nM
The estimate for compound 4 lay 23-fold (1.36 log units) below the measured number, outside the stated range (above it).
By their numbers in this assay, from the lowest: compound 3; then compound 1; then compound 2; then compound 4.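

This place on the saturated chain proves highly sensitive: on an unchanged core in this assay, 3-chlorobenzyl in place of 3-methoxyphenyl gives an 11-fold higher number from compound 2 to compound 4 (1.04 log units; beyond the scatter). The earlier compounds shown here offered no pair that isolated a change here, so the size of this shift could not be seen from them. Nothing measured here accounts for the shift.

The compounds shown leave open whether the chlorine or the longer link to the ring carries this loss. A 3-methoxybenzyl group on the same chain would separate the two.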